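This account rests on a few compounds, and the source may have more. Where it says the series, first, only, none or still open, it means among the compounds named here.

Measured compounds:
- compound 1 `COc1ccc2nccc(C3CN(C4CCN(Cc5cc6ccccc6n5C)CC4)C(=O)O3)c2c1` gives 3160 nM
- compound 2 `COc1ccc2nccc(C3CN(C4CCN(Cc5cc6ccccc6o5)CC4)C(=O)O3)c2c1` gives 1260 nM
- compound 3 `COc1ccc2nccc(C3CN(C4CCN(Cc5cc6ccccc6s5)CC4)C(=O)O3)c2c1` gives 794 nM

These three values come from an in vitro functional assay on RBL cells for antagonist activity at C-C chemokine receptor type 8 (Homo sapiens), read by FLIPR and calcium flux; a higher number here means a weaker inhibitor, a lower number a stronger inhibitor. Compound 3 has the lowest number of the three: its step from compound 2 is a 1.6-fold lower number from compound 2 to compound 3 (0.20 log units; within the scatter), which is within the scatter, while the step from compound 1 is a 4.0-fold lower number from compound 1 to compound 3 (0.60 log units; beyond the scatter), which is beyond it. Compound 1 to compound 2 is a 2.5-fold lower number from compound 1 to compound 2 (0.40 log units; beyond the scatter).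

Compound 4 `COc1ccc2nccc(C3CN(C4CCN(C)CC4)C(=O)O3)c2c1` differs from compound 3 by hydrogen in place of 1-benzothiophen-2-yl on a saturated chain carbon bound to an amine nitrogen in a ring. The measured steps all swap one fused bicyclic ring system for another on that same carbon, and even these swaps moved this assay only modestly. None of them removes the ring system altogether, so they give no direct guide to the size of the change in compound 4; they only show that this part of the molecule matters to the number. Taking away the whole group, leaving only a methyl on the ring nitrogen, is a much larger change than any swap measured, and a clear rise in the number is expected, plausibly past the point where this assay reports only a limit. For compound 4 the expected step is a 38-fold higher number from compound 3 to compound 4 (1.58 log units; beyond the scatter), giving an estimate of 30000 nM, with a range from 5000 nM to 100000 nM.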

Compound 4, half-maximal inhibitory concentration: < 50200 nM
Compound 4 gave a limit, no number; the forecaster's own chance of this, stated with the estimate: 45%; the middle value lies beyond the limit too.
By their numbers in this assay, from the lowest: compounds 3 and 2 (each within the scatter of the next); then compound 1.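

In this assay, compound 4 gives only a limit, < 50200 nM, and not a number. The steps to compound 4 from compound 1, compound 2 and compound 3 therefore cannot be read. The compounds shown leave open how much, and in which direction, going from (1-benzothiophen-2-yl)methyl to methyl changes the number.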